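A few compounds are considered here, and "the series" means these few. Any claim that something is new, unique, unknown or untested is made for them only; others in the source may bear on it.

Measured in a functional assay on HepG2 cells (Homo sapiens) for antiproliferative activity, read by MTT assay; a lower number here means a stronger inhibitor, a higher number a weaker inhibitor:
- compound 1 `CC1(C)CCc2c(ccc(C(=O)/C=C/c3ccc(OCc4cn(-c5ccc(Cl)cc5)nn4)cc3)c2O)O1`: 102000 nM
- compound 2 `CC1(C)CCc2c(ccc(C(=O)/C=C/c3ccc(OCc4cn(-c5ccc(Br)cc5)nn4)cc3)c2O)O1`: 136000 nM
- compound 3 `Cc1c(-n2cc(COc3ccc(/C=C/C(=O)c4ccc5c(c4O)CCC(C)(C)O5)cc3)nn2)cccc1[N+](=O)[O-]`: 115000 nM

Compound 3 gives 115000 nM in this assay, in the same range as the other two compounds, so no ranking among the three can be read from these numbers.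

Compound 4 `COc1ccc(-n2cc(COc3ccc(/C=C/C(=O)c4ccc5c(c4O)CCC(C)(C)O5)cc3)nn2)c([N+](=O)[O-])c1` keeps the shared core but carries 4-methoxy-2-nitrophenyl in place of 2-methyl-3-nitrophenyl on an aromatic nitrogen.

The best guides are the two measured swaps of the group on that same nitrogen, a 1.1-fold higher number from compound 1 to compound 3 (0.05 log units; within the scatter) and a 1.2-fold lower number from compound 2 to compound 3 (0.07 log units; within the scatter). The swap of one halogen for another, a 1.3-fold higher number from compound 1 to compound 2 (0.12 log units; within the scatter), is small as well. For the measured compounds named here, none of the measured compounds carries a methoxy group, so this part of the change is untested. With so little movement so far, no shift beyond the scatter is expected. The expected step, a 1.0-fold higher number from compound 3 to compound 4 (0.01 log units; within the scatter), is only an estimate. Compound 4 is expected to give about 118000 nM, with an estimated range of 60000 nM to 230000 nM.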

Compound 4, half-maximal inhibitory concentration: 120000 nM
Beside the measured number, compound 4's estimate is 1.0-fold (0.01 log units) below it; low and high end bracket the measured number.
By their numbers in this assay, from the lowest: compounds 1, 3, 4 and 2 (each within the scatter of the next).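

Unlike the three earlier groups on this aromatic nitrogen, 4-methoxy-2-nitrophenyl carries a methoxy group, yet in this assay compound 4 stays within the scatter of every earlier compound (a 1.0-fold higher number from compound 3 to compound 4 (0.02 log units; within the scatter)) (a 1.1-fold lower number from compound 2 to compound 4 (0.05 log units; within the scatter)) (a 1.2-fold higher number from compound 1 to compound 4 (0.07 log units; within the scatter)). The range of groups at this place that leave the number unmoved therefore now includes one with a methoxy group, although this swap also changes the other groups on the phenyl ring, so their separate contributions cannot be told apart. No supporting data here explain why the number stays so flat.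

On these data alone, all four compounds carry a substituted phenyl group at this place, so the effect of a simple amine, a carboxylic acid or a longer alkyl chain there remains open. Also open, as far as these compounds go, is whether changes elsewhere on the shared core would move the number beyond the scatter.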